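Moving a nitro group around the ring of compound 1

The compounds below may be only part of what the source reports. "The series", "measured", "known", "first", "only" and "open" are said of these compounds alone.

Compound 1 `c1ccc(C2=NCCN2)cc1` is a small molecule in which a benzene ring carries a cyclic amidine. Among the compounds with values here, in an assay on brain for binding affinity to Amine oxidase [flavin-containing] B (Rattus norvegicus), read by spectrophotometry (on this read-out lower numbers stand for stronger inhibition and higher numbers for weaker inhibition), compound 1 gives 21300 nM, and this is the only actual number among the values shown. Compound 2 `O=[N+]([O-])c1ccc(C2=NCCN2)cc1` carries a nitro group in place of a hydrogen on an aromatic carbon. In this assay compound 2 reaches only the limit > 1000000 nM. The measured step of an at least 46-fold higher number from compound 1 to compound 2 (1.67 log units; beyond the scatter) is therefore large, and one of the two values sits at the boundary described by the limit of > 1000000 nM in this assay, at which 1 of the 2 values shown sits.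

Compound 3 `O=[N+]([O-])c1cccc(C2=NCCN2)c1` differs from compound 1 in one place: nitro in place of hydrogen on an aromatic carbon. The same kind of group enters, so the step from compound 1 to compound 2 is the one that bears on it, and it points toward a clear rise in the number for compound 3, in the direction of weaker inhibition. Compound 3 is expected to show the step of a 14-fold higher number from compound 1 to compound 3 (1.15 log units; beyond the scatter) because the measured step of an at least 46-fold higher number from compound 1 to compound 2 (1.67 log units; beyond the scatter) was large. Compound 3 is accordingly estimated at 300000 nM, with a range from 40000 nM to 2000000 nM.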

Compound 3, inhibition constant: 19300 nM
Estimate against measurement, compound 3: 16-fold (1.19 log units) above; the measured number lies below the stated range.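

In this assay, a nitro group in place of hydrogen on the aromatic carbon meta to a group of 5 heavy atoms gives a 1.1-fold lower number from compound 1 to compound 3 (0.04 log units; within the scatter), so at this position the exchange makes no difference that the assay can resolve. The same exchange on a different aromatic carbon gave an at least 46-fold higher number from compound 1 to compound 2 (1.67 log units; beyond the scatter), which shows that the large loss of inhibition cannot be tied to the nitro group alone: it depends on where on the ring the group sits. The value of compound 2 is a limit, so the true size of its step remains unknown: the limit of > 1000000 nM in this assay, at which 1 of the 3 values shown sits.

With only one group tried at this position, the compounds shown leave open whether the tolerance seen for nitro extends to others, such as an amine, a carboxylic acid or a methoxy group. They also cannot tell whether any group placed here would bring the number down beyond the scatter, or whether such a group would simply match the core of compound 1.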